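The source may report more compounds than this note shows. Statements on the series, on what has been measured and on what is new or still open speak of the compounds shown alone.

Of the compounds shown here, two have so far been measured in a functional assay (Oryctolagus cuniculus) for antagonist activity at platelet-activating factor receptor (Cavia porcellus); a higher number here means a weaker inhibitor, a lower number a stronger inhibitor. Compound 1 `O=C(c1ccn2c1CSC2c1cccnc1)c1c[nH]c2cc(-c3ccc(F)cc3)ccc12` gives 75 nM. Compound 2 `CN(C)C(=O)n1cc(C(=O)c2ccn3c2CSC3c2cccnc2)c2ccc(Cl)cc21` gives 89 nM. Of the two numbers, that of compound 2 is the higher, but the gap to compound 1 falls within the usual scatter of repeated measurements, so the two compounds cannot be told apart on these data.

Compound 3 `CN(C)C(=O)n1cc(C(=O)c2ccn3c2CSC3c2cccnc2)c2ccc(-c3ccccc3)cc21` has not yet been measured in this assay. It differs from compound 2 in one place: phenyl in place of chloro on an aromatic carbon. Within the data shown here, no pair of measured compounds shows this exact exchange, so its effect cannot be read directly from the numbers. Compound 1 does carry an aromatic ring on the same part of the shared core and gives 75 nM, a number within the scatter of compound 2, which suggests that a ring at this position is tolerated. The expected step of a 1.5-fold lower number from compound 2 to compound 3 (0.17 log units; within the scatter) is therefore small and not clearly beyond the scatter. Compound 3 is estimated at 60 nM, with a likely range from 20 nM to 200 nM.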

Compound 3, inhibition constant: 23 nM
Estimate against measurement, compound 3: 2.6-fold (0.42 log units) above, within the range that was stated.
By their numbers in this assay, from the lowest: compound 3; then compounds 1 and 2 (each within the scatter of the next).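

In this assay, putting phenyl in place of chloro gives a 3.9-fold lower number from compound 2 to compound 3 (0.59 log units; beyond the scatter) and so makes compound 3 the stronger inhibitor of this pair. Among these compounds, until now no two measured compounds differed in one place, so nothing could be read about this aromatic carbon; it now appears that the group here does affect the number, and that a single chlorine atom can be exchanged for a six-membered aromatic ring of six carbons without any loss of inhibition. The data at hand offer no explanation for this step.

This one exchange changes the size of the group and adds a ring at the same time, so it cannot separate the two: a non-aromatic ring such as cyclohexyl or an open chain such as n-butyl at the same carbon would help to tell them apart. Also open, going by these compounds, is whether a further group on the added phenyl, such as an amine or a carboxylic acid, would lower the number further, leave it unchanged or raise it.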